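The compounds below may be only part of what the source reports. "The series", "measured", "known", "first", "only" and "open" are said of these compounds alone.

Measured so far:

Compound 1, `O=C(CO[N+](=O)[O-])NNC(=O)c1ccc(-n2[nH]c(=O)cc2-c2ccc(Cl)cc2)cc1`, gives 5.88%.
Compound 2, `O=C(CO[N+](=O)[O-])NNC(=O)c1ccc(-n2[nH]c(=O)cc2-c2ccccc2)cc1`, gives 19.8%.
Compound 3, `CCOC(=O)c1c(-c2ccc(Cl)cc2)n(-c2ccc(C(=O)NNC(=O)CO[N+](=O)[O-])cc2)[nH]c1=O`, gives 3.2%.

These three compounds share a common core and were tested in a functional assay on the whole organism (strain Wistar) for inhibition, with Rattus norvegicus as the target, read by paw edema, with a stated time of 1 h, at a dose of 6 mg/kg by the oral route; on this read-out higher numbers stand for more inhibition at the one dose given (going by the name of the read-out) and lower numbers for less inhibition. Compound 2 differs from compound 1 only by hydrogen in place of chloro on an aromatic carbon, and that single change gave a number 13.9 percentage points higher from compound 1 to compound 2 (beyond the scatter). Compound 3 differs from compound 1 by ethoxycarbonyl in place of hydrogen on an aromatic carbon, a change that gave a number 2.7 percentage points lower from compound 1 to compound 3 (within the scatter). The unmeasured compound 4, `CCOC(=O)c1c(-c2ccccc2)n(-c2ccc(C(=O)NNC(=O)CO[N+](=O)[O-])cc2)[nH]c1=O`, is made from compound 3 by hydrogen in place of chloro on an aromatic carbon, the same change as from compound 1 to compound 2, at the same place. Compound 4 is therefore expected to gain roughly as compound 2 did over compound 1, giving a number 12.8 percentage points higher from compound 3 to compound 4 (beyond the scatter), because compound 3 starts from 3.2% and the earlier step was a number 13.9 percentage points higher from compound 1 to compound 2 (beyond the scatter). The expected result for compound 4 is 16%, within 3% to 30%.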

Compound 4, a percentage reported as inhibition, in the whole organism at one dose (the size of the read-out at that dose, not a potency): 54%
Estimate against measurement, compound 4: 38 percentage points below, and the stated range ends below it.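

Replacing the chloro with hydrogen gave a number 50.8 percentage points higher from compound 3 to compound 4 (beyond the scatter) in this assay, so this change does not carry a fixed gain from one core to another: the same change on two cores in this assay, a number 13.9 percentage points higher (beyond the scatter) from compound 1 to compound 2 and a number 50.8 percentage points higher (beyond the scatter) from compound 3 to compound 4, 36.9 percentage points apart, beyond the scatter of two such steps. The ethoxycarbonyl depends on its partner in the same way, giving a number 34.2 percentage points higher from compound 2 to compound 4 (beyond the scatter) on the phenyl compounds, so the effects of the two changes do not simply add: the same change on two cores in this assay, a number 2.7 percentage points lower (within the scatter) from compound 1 to compound 3 and a number 34.2 percentage points higher (beyond the scatter) from compound 2 to compound 4, 36.9 percentage points apart, beyond the scatter of two such steps. These four compounds show that the two changes work together in this series, but they do not show why, and they cannot predict the result on any other core.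

On these data alone, it remains open whether a carboxylic acid or a methoxycarbonyl in place of the ethoxycarbonyl would give the same pattern. As far as these compounds go, it is also open whether fluoro or methyl in place of the chloro would behave like hydrogen or like chloro.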